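A larger side arm in place of the piperidinyl chain

The compounds below may be only part of what the source reports. "The series", "measured", "known", "first", "only" and "open" are said of these compounds alone.

Compound 2 `c1ccc2c(c1)CN[C@@H](CN(CCCCNC1CCNCC1)[C@H]1CCCc3cccnc31)C2` gives 63.4 nM in a functional assay on cells for antagonist activity at C-X-C chemokine receptor type 4 (Homo sapiens), read by fluorescence and calcium flux, with stated times of 25 min and 90 s (a lower number here means a stronger inhibitor, a higher number a weaker inhibitor), the lowest of the two numbers shown, though only narrowly. Compound 1 `c1ccc2c(c1)CN[C@@H](CN(CCCCNC1CCCCC1)[C@H]1CCCc3cccnc31)C2` gives 75.2 nM in this assay, and the step of a 1.2-fold lower number from compound 1 to compound 2 (0.07 log units; within the scatter) stays within the scatter, so the two compounds cannot be separated on these numbers.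

Compound 3 `CC(C)(CCN(C[C@H]1Cc2ccccc2CN1)[C@H]1CCCc2cccnc21)CNCC1CCOCC1` carries a different change: a group of 12 heavy atoms (10 carbon, 1 nitrogen, 1 oxygen; one six-membered non-aromatic ring with 1 hetero atom) in place of a group of 9 heavy atoms (7 carbon, 2 nitrogen; one six-membered non-aromatic ring with 1 hetero atom), on a saturated chain carbon, two bonds along the chain from an amine nitrogen. Going by the values given here, the only measured step, from compound 1 to compound 2, touched the far amine terminus alone and left the rest of the chain untouched; it offers little direct guidance for a change on the chain carbon itself, where the branched chain and the oxygen-containing ring enter. Among the compounds with values here, the one step available, a 1.2-fold lower number from compound 1 to compound 2 (0.07 log units; within the scatter), was small, which suggests that this part of the molecule tolerates variation without a large movement in this assay.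

Compound 3 is therefore expected to give about 85 nM, with a range from 30 nM to 240 nM. The step of a 1.3-fold higher number from compound 2 to compound 3 (0.13 log units; within the scatter) is expected to remain within the scatter, with a modest lean toward a higher number.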

Compound 3, half-maximal inhibitory concentration: 43.8 nM
The estimate for compound 3 lay 1.9-fold (0.29 log units) above the measured number; the range from low to high includes it.
By their numbers in this assay, from the lowest: compounds 3, 2 and 1 (each within the scatter of the next).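

In this assay the entering group of 12 heavy atoms, on a saturated chain carbon, two bonds along the chain from an amine nitrogen, gives a 1.4-fold lower number from compound 2 to compound 3 (0.16 log units; within the scatter) and, set against the cyclohexyl-bearing group, a 1.7-fold lower number from compound 1 to compound 3 (0.23 log units; within the scatter) as well. Where the earlier step had touched only the far amine terminus, these steps show that a larger exchange, one that brings in the branched chain and an oxygen-containing ring and leaves 1 hydrogen-bond donor where compound 2 has 2, still does not separate compound 3 from either earlier compound. No measurement shown here explains this outcome.

The branched chain and the oxygen-containing ring enter together in compound 3, so the compounds shown leave open what each contributes alone. Also open is whether a longer chain, a morpholine ring or a carboxylic acid at this place would give a step beyond the scatter, since all three compounds shown remain within it of one another.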